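Hydrazone series: pyridin-4-yl in place of 4-chlorophenyl

The source may hold more compounds than are shown below. What is called first, only, known or untested is meant among the compounds shown, and "the series" means these compounds.

Measured so far in a functional assay on the whole organism (strain Wistar) for inhibition, with Rattus norvegicus as the target, read by paw edema, with a stated time of 1 h, at a dose of 10 mg/kg by the intraperitoneal route; a higher number here means more inhibition at the dose given (going by the name of the read-out), a lower number less inhibition:
compound 1 `O=C(N/N=C/c1ccc(F)cc1)c1cccnc1Nc1cccc(C(F)(F)F)c1`, 43.2%
compound 2 `O=C(N/N=C/c1ccc(Cl)cc1)c1cccnc1Nc1cccc(C(F)(F)F)c1`, 67.2%
compound 3 `COc1cccc(/C=N/NC(=O)c2cccnc2Nc2cccc(C(F)(F)F)c2)c1`, 58.8%

Compound 2 gives the highest of the three numbers in this assay. Its margin over compound 3 is a number 8.4 percentage points lower from compound 2 to compound 3 (within the scatter), which is within the scatter, so the two cannot be ordered; its margin over compound 1 is a number 24 percentage points higher from compound 1 to compound 2 (beyond the scatter), which is beyond the scatter. The change from compound 1 to compound 3, a number 15.6 percentage points higher from compound 1 to compound 3 (beyond the scatter), is also beyond the scatter.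

Compound 4 `O=C(N/N=C/c1ccncc1)c1cccnc1Nc1cccc(C(F)(F)F)c1` is not yet measured. It differs from compound 2 as follows: pyridin-4-yl in place of 4-chlorophenyl on a carbon with a double bond to nitrogen. Going by the values given here, none of the measured steps exchanges a phenyl for a pyridinyl; the steps that bear on the same carbon only swap one substituted phenyl for another. Of those, the step from compound 1 to compound 2 was modest and the step from compound 2 to compound 3 stayed within the scatter, so the numbers in this assay have so far been higher or level across changes at this carbon, with no drop beyond the scatter. Among the compounds with values here, the pyridin-4-yl entering has no precedent, so a step is estimated in this assay of a number 15.2 percentage points lower from compound 2 to compound 4 (beyond the scatter), downward, with wide uncertainty because compound 2 stands at 67.2% with nothing closer to compare.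

Compound 4 is therefore expected at 52%, in the range 35% to 68%.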

Compound 4, a percentage reported as inhibition, in the whole organism at one dose (the size of the read-out at that dose, not a potency): 70.2%
The estimate for compound 4 lay 18.2 percentage points below the measured number, and the stated range ends below it.
By their numbers in this assay, from the lowest: compound 1; then compounds 3, 2 and 4 (each within the scatter of the next, the first and the last beyond it).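

In this assay, going by these compounds alone, the carbon with a double bond to nitrogen accepts a ring with a hetero atom: the pyridin-4-yl of compound 4 stays level with the 4-chlorophenyl of compound 2 (a number 3 percentage points higher from compound 2 to compound 4 (within the scatter)), so these two cannot be ordered, and the earlier compounds had only substituted carbon-only rings at this place. The same exchange of ring sits clear of the other two compounds, both with the 3-methoxyphenyl (a number 11.4 percentage points higher from compound 3 to compound 4 (beyond the scatter)) and, by a wider step, with the 4-fluorophenyl (a number 27 percentage points higher from compound 1 to compound 4 (beyond the scatter)), so a ring without any substituent, carrying a ring nitrogen instead, gives up nothing measurable against the best of the substituted phenyl rings at this dose. Nothing available here gives a reason for these steps.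

Still open, on these data alone, is whether the ring nitrogen must sit as in the pyridin-4-yl, which pyridin-3-yl and pyridin-2-yl would test, and whether an unsubstituted phenyl or a saturated ring such as piperidin-4-yl would hold the same level at this carbon. As far as these compounds go, each number is also the size of the read-out at one dose, so the order of the compounds in potency remains open.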